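The compounds below may be only part of what the source reports. "The series", "measured", "known", "first", "only" and "open" are said of these compounds alone.

Measured compounds:
compound 1 `CC(=O)N1CCN(c2ccc(OCc3cc4cnc(C#N)nc4n3CCC3CCCCC3)cc2F)CC1`, 9 nM
compound 2 `CC(=O)N1CCCN(c2ccc(OCc3cc4cnc(C#N)nc4n3CCC3CCCCC3)cc2)CC1`, 11 nM
compound 3 `CC(=O)N1CCN(c2ccc(OCc3cc4cnc(C#N)nc4n3CCC3CCCC3)cc2)CC1`, 5 nM

In an assay on isolated protein for inhibition of cathepsin S (Homo sapiens), read by fluorescence (a higher number here means a weaker inhibitor, a lower number a stronger inhibitor), compound 3 gives the lowest of the three numbers. Its gap to compound 1 lies within the usual scatter, so the two cannot be placed in order; its gap to compound 2 lies beyond it. Compounds 1 and 2 both carry a cyclohexyl at the end of the chain, but each also differs from compound 3 elsewhere, so neither pair isolates the ring size alone.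

Compound 4 `CC(=O)N1CCN(c2ccc(OCc3cc4cnc(C#N)nc4n3CCC3CCCCCC3)cc2)CC1` differs from compound 3 in one place: cycloheptyl in place of cyclopentyl on a saturated chain carbon, two bonds along the chain from an aromatic nitrogen. Cut one bond further out, the change reads cyclopentylmethyl to cycloheptylmethyl. Within the data shown here, the compounds measured so far give no step that bears directly on this change, so there is no measured guide to its size. Given that the three shown values sit close together, the step from compound 3 to compound 4 is expected to be small, a 1.6-fold higher number from compound 3 to compound 4 (0.20 log units; within the scatter), toward a slightly higher number at most. Compound 4 is therefore estimated at 8 nM in this assay, with a range from 3 nM to 25 nM.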

Compound 4, half-maximal inhibitory concentration: 50 nM
Beside the measured number, compound 4's estimate is 6.3-fold (0.80 log units) below it; the whole stated range lies below it.
By their numbers in this assay, from the lowest: compounds 3, 1 and 2 (each within the scatter of the next, the first and the last beyond it); then compound 4.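

In this assay, among these compounds, this is the first change at the end of the chain that can be read on its own, and it is not neutral: cycloheptyl in place of cyclopentyl gives a 10-fold higher number from compound 3 to compound 4 (1.00 log units; beyond the scatter) with the rest of the molecule unchanged. Among the compounds shown here, the ring on this saturated chain carbon, two bonds along the chain from an aromatic nitrogen, therefore affects the measured inhibition, even though the three earlier values gave no sign of a step of this size. No measurement shown here offers an explanation for this step.

From the compounds shown here alone, whether the number climbs steadily with ring size remains open, as cyclohexyl appears only in compound 1 and compound 2, which each differ from compound 3 elsewhere too. Going by these compounds, how a cyclobutyl, a phenyl ring or a longer chain would read at this place is also open.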